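The compounds below may be only part of what the source reports. "The series", "measured", "known", "first", "only" and "open" are said of these compounds alone.

Compound 1 `COc1cc(-c2nnc3n2NC(c2ccco2)C(C(=O)C2CC2)S3)cc(OC)c1OC` carries a cyclopropyl on a carbonyl carbon of the shared core. In a functional assay on MCF7 cells (Homo sapiens) for cytotoxicity, read by MTT assay, with a stated time of 48 h (on this read-out higher numbers stand for weaker inhibition and lower numbers for stronger inhibition), compound 1 gives only a limit, > 100000 nM; this is the limit of > 100000 nM in this assay, at which 1 of the 3 values shown sits. Compound 2 `COc1cc(-c2nnc3n2NC(c2cccs2)C(C(=O)c2ccc(F)cc2)S3)cc(OC)c1OC` gives 43700 nM in this assay, and compound 3 `COc1cc(C(=O)C2Sc3nnc(-c4cc(OC)c(OC)c(OC)c4)n3NC2c2cccs2)cc(OC)c1OC` gives 71000 nM; the step of a 1.6-fold higher number from compound 2 to compound 3 (0.21 log units; within the scatter) is the only measured one. Compound 4 `COc1cc(-c2nnc3n2NC(c2ccco2)C(C(=O)c2ccc(-c4ccccc4)cc2)S3)cc(OC)c1OC` is compound 1 with 4-phenylphenyl in place of cyclopropyl on a carbonyl carbon. Among the measured compounds shown here, no measured step exchanges cyclopropyl for an aryl group, so the nearest guide is compound 2 at 43700 nM together with compound 3 at 71000 nM, both numbers rather than limits. Compound 4 is therefore expected to give 60000 nM in this assay, between 15000 nM and 200000 nM. That estimate means an expected step of an at least 1.6-fold lower number from compound 1 to compound 4 (0.22 log units; that floor lies within the scatter), though a limit remains possible.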

Compound 4, half-maximal inhibitory concentration: > 100000 nM
Compound 4: a limit, no number (the forecaster's own chance of this, stated with the estimate: 35%); at least 1.6-fold (0.22 log units) between middle value and limit.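

Among the compounds shown here, compound 1 and compound 4 both end at a limit of the assay rather than a number, so no step between them can be read: the limit of > 100000 nM in this assay, at which 2 of the 4 values shown sit. In this assay the compounds shown leave open whether 4-phenylphenyl or cyclopropyl on a carbonyl carbon gives stronger inhibition.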